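The compounds below may be only part of what the source reports. "The series", "measured", "known", "first", "only" and "open" are said of these compounds alone.

Compound 1 `Cc1cc(NC(=O)Nc2ccc(C(C)(C)C)cc2)c2ccccc2n1` was tested in an ADME assay on HepG2 cells (Homo sapiens) for cytotoxicity, with a stated time of 72 h (a higher number here means that more compound is needed for the effect, a lower number that less compound is needed), where compound 1 gives 17000 nM. Compound 2 `CSc1ccc(NC(=O)Nc2cc(C)nc3ccccc23)cc1` carries the same core, and in this assay compound 2 gives 16000 nM. The change between them, (methylsulfanyl in place of tert-butyl on an aromatic carbon), made the step of a 1.1-fold lower number from compound 1 to compound 2 (0.03 log units; within the scatter), so the two values show nothing that can be told apart.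

Compound 3 `Cc1cc(NC(=O)Nc2ccccc2C(C)(C)C)c2ccccc2n1` is built from the same atoms as compound 1, but joined differently; how the two cores differ is not broken down here. In this assay compound 3 reaches only a limit, > 25000 nM, which is the limit of > 25000 nM in this assay, at which 1 of the 3 values shown sits, and not a number.

Compound 4 `CSc1ccccc1NC(=O)Nc1cc(C)nc2ccccc12` has not yet been measured. It differs from compound 3 by methylsulfanyl in place of tert-butyl on an aromatic carbon. Going by the values given here, this is the same kind of change as the one from compound 1 to compound 2, but not the same: in compound 2 the entering group sits para to a large group, whereas in compound 4 it sits ortho to a large group.

With compound 3 known only as a limit, and the earlier step from compound 1 to compound 2 lying within the scatter, compound 4 is expected to stay near where compound 3 stands, a step that the limit leaves unreadable from compound 3 to compound 4. The estimate for compound 4 in this assay is 30000 nM, expected to fall between 14000 nM and 80000 nM, with a fair chance that only a limit is reported.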

Compound 4, half-maximal effective concentration: > 25000 nM
Compound 4: a limit, no number (the forecaster's own chance of this, stated with the estimate: 60%); the middle value lies beyond the limit too.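

In this assay compound 4 gives > 25000 nM, which is a limit and not a number. Compound 3 also stands only at a limit, so no step can be read between the two: the limit of > 25000 nM in this assay, at which 2 of the 4 values shown sit.

The compounds shown leave open how far methylsulfanyl in place of tert-butyl, ortho to a large group, shifts the number in this assay, if it shifts it at all.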